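Series notes: methyl in place of isopropyl, second instance

The source may report more compounds than this note shows. Statements on the series, on what has been measured and on what is new or still open speak of the compounds shown alone.

In a functional assay for inhibition of Polyunsaturated fatty acid 5-lipoxygenase (Homo sapiens) (on this read-out higher numbers stand for an effect only at larger amounts of compound and lower numbers for an effect already at smaller amounts), compound 1 `CN(O)C(=O)NCCSc1nc2ccccc2s1` gives 90 nM, compound 2 `CC(C)N(O)C(=O)NCCSc1nc2ccccc2s1` gives 130 nM and compound 3 `CC(C)N(O)C(=O)NCCCSc1nc2ccccc2s1` gives 70 nM; all three values lie within the scatter of one another. Compound 2 and compound 1 differ by methyl in place of isopropyl on an amide-type nitrogen, a change that made a 1.4-fold lower number from compound 2 to compound 1 (0.16 log units; within the scatter). How the cores of compound 2 and compound 3 differ is not broken down here. Compound 4 `CN(O)C(=O)NCCCSc1nc2ccccc2s1` is not yet measured in this assay; it differs from compound 3 by methyl in place of isopropyl on an amide-type nitrogen, the same change at the same kind of place as in the measured pair. For the measured compounds named here, the expected step is a 1.3-fold lower number from compound 3 to compound 4 (0.10 log units; within the scatter), because the matching step already gave a 1.4-fold lower number from compound 2 to compound 1 (0.16 log units; within the scatter) and no other measured pair bears on it. For compound 4 the estimated value in this assay is 55 nM, with 25 nM to 130 nM as the expected range.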

Compound 4, half-maximal effective concentration: 45 nM
For compound 4 the middle estimate is 1.2-fold (0.09 log units) above the measured one, and the stated range covers the measured number.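

In this assay, methyl in place of isopropyl on an amide-type nitrogen gives a 1.6-fold lower number from compound 3 to compound 4 (0.19 log units; within the scatter), and the step reads alike on the two cores: the same change on two cores in this assay, a 1.4-fold lower number (0.16 log units; within the scatter) from compound 2 to compound 1 and a 1.6-fold lower number (0.19 log units; within the scatter) from compound 3 to compound 4, 1.1-fold (0.03 log units) apart, within the scatter of two such steps. Within this series, the change can thus be carried between these two cores with no detectable difference in the size of the step. Neither step lies beyond the scatter, so this shows no real gain from methyl, and two cores cannot establish that the step holds on others.

The compounds shown leave open what an ethyl, a tert-butyl or a phenyl on that nitrogen would give. Also open, going by these compounds, is how a longer chain in the core would read.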